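The compounds below may be only part of what the source reports. "The series", "measured", "known", "first", "only" and "open" are said of these compounds alone.

Compound 1 `Clc1ccc(C2ON=C(c3ccccc3Cl)O2)cc1Cl`: in an ADME assay on HEK293 cells (Homo sapiens) for cytotoxicity, read by MTT assay, with a stated time of 44 h (on this read-out higher numbers stand for weaker inhibition and lower numbers for stronger inhibition), compound 1 gives a limit, > 100000 nM
Compound 2 `CC1(c2cccc(Br)c2)ON=C(c2ccccc2Cl)O1`: compound 2 gives a limit, > 100000 nM
Compound 3 `Clc1cccc(C2=NOC(c3ccc(Cl)c(Cl)c3)O2)c1`: compound 3 gives a limit, > 100000 nM

None of these three values is a true number; each is a limit of the assay. Compound 3 therefore stands exactly where the other two stand, at the limit that all three share (the limit of > 100000 nM in this assay, at which 3 of the 3 values shown sit).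

Compound 4 `Clc1ccc(C2ON=C(c3cccc(Cl)c3)O2)cc1` differs from compound 3 by hydrogen in place of chloro on an aromatic carbon. Going by the values given here, no measured pair differs in one place, so no measured step shows how much such a change moves this read-out. Since compound 3 sits at the limit > 100000 nM, the step from compound 3 to compound 4 is expected to be none beyond the scatter a step that the limit leaves unreadable from compound 3 to compound 4. Compound 4 is estimated to give 150000 nM, within 80000 nM to 400000 nM, most likely reported again only as a limit.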

Compound 4, half-maximal inhibitory concentration: > 100000 nM
Compound 4: no number, only a limit (the forecaster's own chance of this, stated with the estimate: 85%); the middle value is on the limit's open side.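

Compound 3 and compound 4 both give only a limit, so no step between them can be read: the limit of > 100000 nM in this assay, at which 4 of the 4 values shown sit.

The compounds shown leave open what the true value of each one is, and whether hydrogen in place of chloro changes it at all.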